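Microsomal clearance notes: cyclopropylphenyl in place of ethynylphenyl

The compounds below may be only part of what the source reports. "The series", "measured", "known", "first", "only" and "open" are said of these compounds alone.

Measured so far in an ADME assay on microsomes from liver (Rattus norvegicus) for metabolic stability, read by LC-MS, using NADPH, with a stated time of 10 min, tested at 0.1 uM; a lower number here means slower removal, a higher number faster removal of the compound:
compound 1 `O=C(NCCCCn1cccn1)c1cccc(C2SCC(=O)N2c2ccccn2)c1` gives 506 mL.min-1.g-1
compound 2 `O=C(NCCCCc1ccccc1)c1cccc(C2SCC(=O)N2c2cccc(F)c2)c1` gives 3240 mL.min-1.g-1
compound 3 `C#Cc1cccc(N2C(=O)CSC2c2cccc(C(=O)NCCCCc3ccccc3)c2)c1` gives 1820 mL.min-1.g-1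

Compound 3 stands second highest of the three numbers in this assay. Compound 2 lies within the scatter of it, while compound 1 lies beyond the scatter at a lower number. Compound 4 `O=C(NCCCCc1ccccc1)c1cccc(C2SCC(=O)N2c2ccc(C3CC3)cc2)c1` differs from compound 3 in one place: 4-cyclopropylphenyl in place of 3-ethynylphenyl on an amide-type nitrogen in a ring. Among the compounds with values here, the only measured step that touches the group on this amide-type nitrogen in a ring is a 1.8-fold lower number from compound 2 to compound 3 (0.25 log units; within the scatter), which stayed within the scatter. Within the data shown here, no measured pair carries a cyclopropylphenyl group, so the data give no direction for the new group. Compound 4 is therefore expected to sit close to compound 3 in this assay, with the step of a 1.1-fold higher number from compound 3 to compound 4 (0.04 log units; within the scatter) expected to remain within the scatter. The estimate for compound 4 is 2000 mL.min-1.g-1, with a range from 900 mL.min-1.g-1 to 4500 mL.min-1.g-1.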

Compound 4, intrinsic clearance in microsomes: 2280 mL.min-1.g-1
Estimate against measurement, compound 4: 1.1-fold (0.06 log units) below; the range from low to high includes it.
By their numbers in this assay, from the lowest: compound 1; then compounds 3, 4 and 2 (each within the scatter of the next).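

In this assay the new group gives a 1.3-fold higher number from compound 3 to compound 4 (0.10 log units; within the scatter), and against the fluorinated analogue it gives a 1.4-fold lower number from compound 2 to compound 4 (0.15 log units; within the scatter); both steps stay within the scatter. The group on the amide-type nitrogen in a ring now has three forms on the shared core, 3-fluorophenyl, 3-ethynylphenyl and 4-cyclopropylphenyl, and their numbers in this assay cannot be told apart, even with a three-membered ring entering and the substituent named at a different ring number. No measurement at hand accounts for this agreement.

As far as these compounds go, whether an amine or a carboxylic acid on this phenyl ring would carry the number beyond the scatter stays open. Within the data shown here, also open is whether the same agreement would hold with the amide side chain of compound 1 in place of the one shared by compounds 2, 3 and 4.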